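From Neopentyl to Cyclobutyl on an Amine Nitrogen

The source may report more compounds than this note shows. Statements on the series, on what has been measured and on what is new or still open speak of the compounds shown alone.

Of the compounds shown here, two have so far been tested in an in vitro ADME assay on microsomes from liver (Homo sapiens) for pharmacokinetics; a higher number here means faster removal of the compound, a lower number slower removal: compound 1 (`CCCN1CC[C@H](NC(=O)C[C@@H]2C(=O)NC=CN2S(=O)(=O)c2ccc(C)cc2)C(C)(C)C1`) and compound 2 (`Cc1ccc(S(=O)(=O)N2C=CNC(=O)[C@H]2CC(=O)N[C@H]2CCN(CC(C)(C)C)CC2(C)C)cc1`). In this assay compound 1 gives only a limit, < 50 mL.min-1.g-1, and no number. Going by the values given here, compound 2 gives 405 mL.min-1.g-1 as the only actual number so far. Compound 3 (`Cc1ccc(S(=O)(=O)N2C=CNC(=O)[C@H]2CC(=O)N[C@H]2CCN(C3CCC3)CC2(C)C)cc1`) remains unmeasured and carries cyclobutyl in place of neopentyl on an amine nitrogen in a ring. Among the compounds with values here, the only measured step that bears on this is an at least 8.1-fold higher number from compound 1 to compound 2 (0.90 log units; beyond the scatter), with tert-butyl in place of ethyl on a saturated chain carbon bound to an amine nitrogen in a ring. Given that step to compound 2 at 405 mL.min-1.g-1, compound 3, which lacks the neopentyl group, is expected to recover part of it, with a lower number. The expected change is a 3.4-fold lower number from compound 2 to compound 3 (0.53 log units; beyond the scatter) in all. Compound 3 is estimated at 120 mL.min-1.g-1, with an expected range of 45 mL.min-1.g-1 to 320 mL.min-1.g-1 in this assay.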

Compound 3, intrinsic clearance in microsomes: 24 mL.min-1.g-1
Compound 3: the middle estimate sits 5.0-fold (0.70 log units) above what was measured; the whole stated range lies above it.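

The exchange of neopentyl for cyclobutyl on the amine nitrogen in a ring gives, in this assay, a 17-fold lower number from compound 2 to compound 3 (1.23 log units; beyond the scatter). Going by these compounds alone, compound 3 gives a second actual number, 24 mL.min-1.g-1, so the size of a change at this nitrogen can now be stated in full for the first time. Compound 1 gives only a limit, and the step to compound 3, with cyclobutyl in place of propyl, cannot be read: the limit of < 50 mL.min-1.g-1 in this assay, at which 1 of the 3 values shown sits.

The compounds shown leave open whether the low number goes with any carbon ring on this nitrogen or with cyclobutyl alone, which cyclopropyl or cyclopentyl there would help to settle. Also open, from the compounds shown here alone, is how isopropyl, a branched group without a ring, or an oxetane ring at the same nitrogen would compare.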